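A few compounds are considered here, and "the series" means these few. Any claim that something is new, unique, unknown or untested is made for them only; others in the source may bear on it.

Compound 2 `Cc1nc(C#Cc2ccc(C(=O)N[C@H](C)C(C)(C)O)nc2)cs1` is the reference point for this step. Within the data shown here, in a functional assay on HEK293 cells for positive allosteric modulation of metabotropic glutamate receptor 5 (Rattus norvegicus), read by fluorescence and calcium flux (a higher number here means a larger maximal response, a lower number a smaller maximal response), compound 2 gives 66.6%, the highest of the two numbers measured so far, and its nearest neighbour on the numbers is compound 1 `C[C@@H](NC(=O)c1ccc(C#Cc2cc(F)cc(F)c2)cn1)C(C)(C)O`, which gives 61.6% in this assay; the gap a number 5 percentage points higher from compound 1 to compound 2 (within the scatter) lies within the scatter.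

Compound 3 `C[C@@H](NC(=O)c1ccc(C#CC2CC2)cn1)C(C)(C)O` is the next compound awaiting measurement in this assay. It differs from compound 2 by cyclopropyl in place of 2-methyl-1,3-thiazol-4-yl on a triple-bonded carbon.

Among the measured compounds shown here, only one measured step bears on this position, the step of a number 5 percentage points higher from compound 1 to compound 2 (within the scatter), in which a group on the same triple-bonded carbon was exchanged and the maximal response did not move beyond the scatter. For the measured compounds named here, that step swapped one aromatic ring for another aromatic ring; no measured step yet exchanges an aromatic ring for a three-membered non-aromatic ring of carbon only, so the earlier step gives only a weak pointer. For compound 3 the expectation is therefore no step beyond the scatter, and the estimated step is a number 8.6 percentage points lower from compound 2 to compound 3 (within the scatter). The maximal response of compound 3 in this assay is estimated at 58%, with a range from 38% to 78%.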

Compound 3, largest response reached (reported as efficacy), in percent of the reference or control that the assay uses: 63.4%
Beside the measured number, compound 3's estimate is 5.4 percentage points below it; the measured number falls inside the stated range.
By their numbers in this assay, from the lowest: compounds 1, 3 and 2 (each within the scatter of the next).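

Working notes on the group on the triple-bonded carbon: in this assay, the cyclopropyl group of compound 3 gives a number 3.2 percentage points lower from compound 2 to compound 3 (within the scatter) and a number 1.8 percentage points higher from compound 1 to compound 3 (within the scatter), so this replacement stays within the scatter against both aromatic groups. Among these compounds, the earlier pair exchanged only one aromatic ring for another, whereas these steps show that, across the three compounds on the shared core, the maximal response does not depend on an aromatic ring at this place, since a three-membered non-aromatic ring of carbon only serves as well. The same holds for group size and acceptor count as printed for these groups: 3 heavy atoms and 0 hydrogen-bond acceptors in cyclopropyl against 6 heavy atoms and 2 hydrogen-bond acceptors in 2-methyl-1,3-thiazol-4-yl make no difference beyond the scatter, and no available evidence accounts for this.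

Open, from the compounds shown here alone, is whether an amine, a carboxylic acid or a longer open carbon chain on the same triple-bonded carbon would also stay within the scatter. Also open is whether any group at this place can move the maximal response beyond the scatter at all, as every step shown here stays inside it.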